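The compounds below may be only part of what the source reports. "The series", "measured", "known", "first", "only" and "open" are said of these compounds alone.

In an assay on isolated protein for inhibition of dual specificity protein phosphatase 3 (Homo sapiens) (on this read-out lower numbers stand for stronger inhibition and higher numbers for weaker inhibition), three members of this series have been measured. Compound 1 `CCCc1sc(NS(=O)(=O)/C=C/c2ccc(-c3ccccc3)cc2)nc1-c1ccc(Cl)cc1` gives 27000 nM, compound 2 `CCCc1sc(NS(=O)(=O)/C=C/c2ccccc2Cl)nc1-c1ccc(-c2ccccc2)cc1` gives 82000 nM, and compound 3 `Cc1sc(NS(=O)(=O)/C=C/c2ccc(F)c(F)c2)nc1-c1ccc(Cl)cc1` gives 43000 nM. Compound 3 stands second highest of the three numbers; its nearest neighbour is compound 1, whose number is lower but within the scatter, and the furthest is compound 2, whose number is higher yet also within the scatter, so the three values cannot be ordered with confidence.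

The next compound, compound 4 `Cc1sc(NS(=O)(=O)/C=C/c2ccccc2Cl)nc1-c1ccc(Cl)cc1`, is drawn from compound 3 by a single change: 2-chlorophenyl in place of 3,4-difluorophenyl on a double-bonded chain carbon bound to a double-bonded chain carbon. Within the data shown here, no step between measured compounds matches this swap. Among the measured compounds shown here, the only other compound carrying 2-chlorophenyl on the double-bonded chain carbon is compound 2, which differs from compound 3 in two further places, so its value is a weak guide. Because compound 2 gives 82000 nM, a small shift toward a higher number in this assay seems plausible, though it is expected to remain within the scatter. Compound 4 is therefore expected to give about 55000 nM, with a range from 25000 nM to 120000 nM, which corresponds to an estimated step of a 1.3-fold higher number from compound 3 to compound 4 (0.11 log units; within the scatter).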

Compound 4, half-maximal inhibitory concentration: > 100000 nM
Compound 4 gave a limit, no number; the forecaster's own chance of this, stated with the estimate: 15%; at least 1.8-fold (0.25 log units) between middle value and limit.
By their numbers in this assay, from the lowest: compounds 1, 3 and 2 (each within the scatter of the next, the first and the last beyond it). At a limit, above all of these: compound 4.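

In this assay, the series gains its first single-place step: 2-chlorophenyl in place of 3,4-difluorophenyl on a double-bonded chain carbon bound to a double-bonded chain carbon gives an at least 2.3-fold higher number from compound 3 to compound 4 (0.36 log units; beyond the scatter). Compound 4 reached a limit of the assay, > 100000 nM, and not a number. The earlier compounds shown here differed from one another in more than one place and could not tie any shift to this aryl group, whereas this pair shows that the aryl group alone can move the read-out beyond the scatter, with the step's true size left unfixed because one end of it is a limit: the limit of > 100000 nM in this assay, at which 1 of the 4 values shown sits.

As far as these compounds go, it remains open which part of the swap carries the step, the loss of the two fluorines or the arrival of the chlorine, and whether the same swap would have a like effect in a compound carrying the propyl chain of compound 1 instead of the methyl group. Also open, from the compounds shown here alone, is whether a phenyl ring bearing a carboxylic acid or an amine in this place would give a lower number than compound 3.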